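The compounds below may be only part of what the source reports. "The series", "measured", "known", "first", "only" and "open" are said of these compounds alone.

Compound 1 `O=C(Nc1ccc(F)c(Cl)c1)c1ccc(F)c(S(=O)(=O)N2CCCCCC(O)C2)c1`: 11000 nM
Compound 2 `O=C(Nc1ccc(F)c(Cl)c1)c1ccc(F)c(S(=O)(=O)N2CCCCC(O)CC2)c1`: 24000 nM
Compound 3 `CN1CCN(S(=O)(=O)c2cc(C(=O)Nc3ccc(F)c(Cl)c3)ccc2F)CC(O)C1`: 31000 nM

Three compounds sharing one core have been run in an ADME assay on HepG2 2.2.15 cells (Homo sapiens) for cytotoxicity, read by luminescence, with a stated time of 3 days; on this read-out higher numbers stand for lower toxicity in this test and lower numbers for higher toxicity in this test. Compound 1 gives 11000 nM, the lowest of the three numbers. Compound 2 gives 24000 nM and compound 3 gives 31000 nM, and the corresponding steps are a 2.2-fold higher number from compound 1 to compound 2 (0.34 log units; beyond the scatter) and a 2.8-fold higher number from compound 1 to compound 3 (0.45 log units; beyond the scatter). Between the other two the step is a 1.3-fold higher number from compound 2 to compound 3 (0.11 log units; within the scatter).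

Compound 4 `CC1(O)CCCN(S(=O)(=O)c2cc(C(=O)Nc3ccc(F)c(Cl)c3)ccc2F)CC1` differs from compound 1 at the same place as those two: a group of 9 heavy atoms (7 carbon, 1 nitrogen, 1 oxygen; one seven-membered non-aromatic ring with 1 hetero atom) in place of a group of 9 heavy atoms (7 carbon, 1 nitrogen, 1 oxygen; one eight-membered non-aromatic ring with 1 hetero atom), on a sulfonyl sulfur. Both measured steps that bear on this change, a 2.2-fold higher number from compound 1 to compound 2 (0.34 log units; beyond the scatter) and a 2.8-fold higher number from compound 1 to compound 3 (0.45 log units; beyond the scatter), exchanged the ring on the sulfonyl sulfur and each produced a modestly higher number. A modest rise of similar size, or none beyond the scatter, is therefore expected in this assay for compound 4. Compound 4 is estimated to give 18000 nM, with a range from 8000 nM to 40000 nM, which means an expected step of a 1.6-fold higher number from compound 1 to compound 4 (0.21 log units; within the scatter).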

Compound 4, half-maximal cytotoxic concentration: 11000 nM
Beside the measured number, compound 4's estimate is 1.6-fold (0.21 log units) above it; measured number inside the range.
By their numbers in this assay, from the lowest: compounds 1 and 4 (each within the scatter of the next); then compounds 2 and 3 (each within the scatter of the next).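

In this assay, exchanging the ring on the sulfonyl sulfur does not always raise the number: 4-hydroxy-4-methylazepan-1-yl gives no change at the digits printed from compound 1 to compound 4 (within the scatter), unlike the two earlier exchanges. The same group also falls short of both other rings, with a 2.8-fold lower number from compound 3 to compound 4 (0.45 log units; beyond the scatter) and a 2.2-fold lower number from compound 2 to compound 4 (0.34 log units; beyond the scatter), so ring size alone does not sort these compounds: the two seven-membered rings stand apart, as do the two eight-membered rings, while a seven-membered and an eight-membered ring show no change. Nothing available here accounts for these differences.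

Every ring shown carries a hydroxy group, so the compounds leave open how the number would respond to an amine or a carboxylic acid in its place. They also leave open whether the second ring nitrogen in compound 3 would keep its effect in a six-membered ring.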